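Lengthening a Short Chain on the Amine by One Carbon

The compounds below may be only part of what the source reports. "The series", "measured", "known", "first", "only" and "open" are said of these compounds alone.

Three compounds that share one core and differ only in a short chain on an amine nitrogen have been measured in an ADME assay on CHO-K1 cells (Cricetulus griseus) for activation, read by fluorescence, tested at 10 uM; on this read-out lower numbers stand for a stronger effect and higher numbers for a weaker effect at the one concentration tested. Compound 1 `COc1cc(/C=C/C(=O)/C=C(/C=C/c2ccc(O)c(OC)c2)NCCO)ccc1O` gives 90.9%, compound 2 `COc1cc(/C=C/C(=O)/C=C(/C=C/c2ccc(O)c(OC)c2)NCCCO)ccc1O` gives 89.9%, and compound 3 `COCCNC(=C\C(=O)/C=C/c1ccc(O)c(OC)c1)/C=C/c1ccc(O)c(OC)c1` gives 84.4%. Compound 3 stands at the lower edge of this narrow spread, but a number 6.5 percentage points lower from compound 1 to compound 3 (within the scatter) and a number 5.5 percentage points lower from compound 2 to compound 3 (within the scatter), so the three numbers cannot be told apart.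

Compound 4 `COCCCNC(=C\C(=O)/C=C/c1ccc(O)c(OC)c1)/C=C/c1ccc(O)c(OC)c1` has not yet been measured. Against compound 3 the change is this: methoxymethyl in place of methoxy on a saturated chain carbon, two bonds along the chain from an amine nitrogen. For the measured compounds named here, the measured step most like it is the one from compound 1 to compound 2, where a hydroxy became a hydroxymethyl at the same place and a number 1 percentage points lower from compound 1 to compound 2 (within the scatter). The change at this position from compound 2 to compound 3 also gave a number 5.5 percentage points lower from compound 2 to compound 3 (within the scatter). A step of a number 0.6 percentage points higher from compound 3 to compound 4 (within the scatter) is therefore expected, nothing beyond the scatter. Compound 4 is estimated at 85%, with a range from 75% to 95%.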

Compound 4, a percentage reported as activity, at one concentration (the size of the read-out at that concentration, not a potency): 81.2%
The estimate for compound 4 lay 3.8 percentage points above the measured number; low and high end bracket the measured number.
By their numbers in this assay, from the lowest: compounds 4, 3, 2 and 1 (each within the scatter of the next).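

Moving from 2-methoxyethyl to 3-methoxypropyl on the amine nitrogen gives a number 3.2 percentage points lower from compound 3 to compound 4 (within the scatter) in this assay, so the added carbon leaves the ether-capped chain as indistinguishable as the hydroxy-ended chains were. Compound 4 also supplies a second case of methyl in place of hydrogen on the chain oxygen, with a number 8.7 percentage points lower from compound 2 to compound 4 (within the scatter), and the two cases agree: the same change on two cores in this assay, a number 6.5 percentage points lower (within the scatter) from compound 1 to compound 3 and a number 8.7 percentage points lower (within the scatter) from compound 2 to compound 4, 2.2 percentage points apart, within the scatter of two such steps. Even the combined change, which gives a number 9.7 percentage points lower from compound 1 to compound 4 (within the scatter), stays inside the scatter, so neither chain length nor capping the oxygen has yet shifted the read-out measurably at this position.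

Going by these compounds, whether any group here can shift this number beyond the scatter remains open, for example an amine or a carboxylic acid at the chain end, or a longer chain. With one tested concentration, these numbers speak only of a stronger or weaker effect at that concentration.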